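A Methoxy Group Added Beside the Hydroxamate

The compounds below may be only part of what the source reports. "The series", "measured", "known", "first", "only" and "open" are said of these compounds alone.

Three hydroxamic acids share one core and differ at the far end of the benzyl ether. In an assay on isolated protein for inhibition of sphingomyelin phosphodiesterase (Homo sapiens), read by fluorescence, with a stated time of 30 min (a lower number here means a stronger inhibitor, a higher number a weaker inhibitor), compound 1 `CCCCCCc1ccc(COc2cccc(C(=O)NO)c2)cc1` gives 2110 nM. Compound 2 `O=C(NO)c1cccc(OCc2ccc(-c3ccc(Cl)cc3)cc2)c1` gives 8960 nM in this assay, and compound 3 `O=C(NO)c1cccc(OCc2ccc(-c3cccnc3)cc2)c1` gives 52300 nM. Among these three numbers compound 2 stands second highest: it is a 4.2-fold higher number from compound 1 to compound 2 (0.63 log units; beyond the scatter), and a 5.8-fold higher number from compound 2 to compound 3 (0.77 log units; beyond the scatter). The remaining pair shows a 25-fold higher number from compound 1 to compound 3 (1.39 log units; beyond the scatter).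

Compound 4 `COc1ccc(C(=O)NO)cc1OCc1ccc(-c2ccc(Cl)cc2)cc1` is not yet measured. It differs from compound 2 by methoxy in place of hydrogen on an aromatic carbon, on a six-membered aromatic ring of carbon only, ortho to a large group and para to the hydroxycarbamoyl group. Every measured step here replaces the group at the distal end of the benzyl ether; none alters the ring that carries the hydroxycarbamoyl group. The measured steps therefore do not bear on this change, and there is no basis in these data for expecting a step beyond the scatter in either direction.

Compound 4 is consequently expected to give about 9000 nM in this assay, within a range of 3000 nM to 27000 nM. That estimate implies a 1.0-fold higher number from compound 2 to compound 4 (0.00 log units; within the scatter), a change expected to sit inside the usual scatter.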

Compound 4, half-maximal inhibitory concentration: 340 nM
For compound 4 the middle estimate is 26-fold (1.42 log units) above the measured one; measured number outside the range, below it.
By their numbers in this assay, from the lowest: compound 4; then compound 1; then compound 2; then compound 3.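

In this assay, the ring that carries the hydroxycarbamoyl group turns out to be a place where one small change moves the number strongly: methoxy, with its 2 heavy atoms, in place of hydrogen gives a 26-fold lower number from compound 2 to compound 4 (1.42 log units; beyond the scatter). The earlier steps shown here all replaced the group at the distal end of the benzyl ether, and the largest of them, a 25-fold higher number from compound 1 to compound 3 (1.39 log units; beyond the scatter), is about the same size as this one, so the two parts of the molecule can both shift the number substantially. Nothing available bears on the reason for the new step.

From the compounds shown here alone, it remains open whether a hydroxy group, an ethoxy group or a chlorine atom in the same place, ortho to a large group and para to the hydroxycarbamoyl group, would lower the number in the same way, or whether methoxy on another carbon of that ring would do so. Going by these compounds, it also remains open whether methoxy would give a step of this size with hexyl or pyridin-3-yl at the distal end, as these groups stand in compound 1 and compound 3.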